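This account rests on a few compounds, and the source may have more. Where it says the series, first, only, none or still open, it means among the compounds named here.

Compound 1 `COc1ccc(-c2c(-c3cc(OC)c(OC)c(OC)c3)noc2NC(C)=O)cc1OC` – 19800 nM
Compound 2 `COc1ccc(-c2c(-c3cc(OC)c(OC)c(OC)c3)noc2N(C(C)=O)C(C)=O)cc1` – 430 nM

In a functional assay on A549 cells (Homo sapiens) for cytotoxicity, read by MTT assay, with a stated time of 48 h (a lower number here means a stronger inhibitor, a higher number a weaker inhibitor), compound 2 at 430 nM holds the lower of the two numbers, and the gap up to compound 1 lies beyond the scatter. Compound 3 `COc1ccc(-c2c(-c3cc(OC)c(OC)c(OC)c3)noc2N(C(C)=O)C(C)=O)cc1OC` follows from compound 2 by a single change: methoxy in place of hydrogen on an aromatic carbon (methoxy in place of hydrogen on an aromatic carbon, 4-methoxyphenyl to 3,4-dimethoxyphenyl).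

Within the data shown here, no measured pair shows this change alone, so any expectation is loose. Compound 1 also carries the 3,4-dimethoxyphenyl group and gives 19800 nM and that leans the expectation toward a weaker number. In this assay the expected change is a moderate weakening, estimated as a 2.3-fold higher number from compound 2 to compound 3 (0.37 log units; beyond the scatter) with wide uncertainty. For compound 3 the estimated value is 1000 nM within an expected range of 220 nM to 4500 nM in this series.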

Compound 3, half-maximal inhibitory concentration: > 50000 nM
Compound 3 gave a limit, no number; the forecaster's own chance of this, stated with the estimate: 3%; at least 50-fold (1.69 log units) between middle value and limit.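

Compound 3 gives only a limit, not a number, in this assay: the limit of > 50000 nM in this assay, at which 1 of the 3 values shown sits.

On the 4-methoxyphenyl group, the added methoxy, ortho to a methoxy group, brings an at least 110-fold higher number from compound 2 to compound 3 (2.06 log units; beyond the scatter), so in this pair the change to 3,4-dimethoxyphenyl is far from neutral. With 3,4-dimethoxyphenyl held in place, acetyl in place of the amide hydrogen brings an at least 2.5-fold higher number from compound 1 to compound 3 (0.40 log units; beyond the scatter), so the second acetyl does not restore a low number on this ring.

On these data alone, whether a hydroxy group or an amine at this same place would keep a number close to that of compound 2 remains open. Among these compounds, the effect of the second acetyl on the 4-methoxyphenyl compounds also remains open, as no single-place pair shows it.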